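This account rests on a few compounds, and the source may have more. Where it says the series, first, only, none or still open, it means among the compounds named here.

Measured compounds in an ADME assay on cells (Homo sapiens) for cytotoxicity, read by polymerase chain reaction, with a stated time of 3 days; on this read-out lower numbers stand for higher toxicity in this test and higher numbers for lower toxicity in this test:

Compound 1 `Nc1nc(Cl)c(-c2ncco2)c(N[C@@H]2C[C@H](CO)[C@@H](O)[C@H]2O)n1`: > 25000 nM, a limit of the assay.
Compound 2 `Cc1nc(N(C)C)nc(N[C@@H]2C[C@H](CO)[C@@H](O)[C@H]2O)c1-c1nc2ccccc2s1`: 18000 nM.
Compound 3 `CCc1nc(N(C)C)nc(N[C@@H]2C[C@H](CO)[C@@H](O)[C@H]2O)c1-c1nc2ccccc2s1`: > 25000 nM, a limit of the assay.

Among the compounds with values here, compound 2 carries the only number in this assay; the other two values are limits. Within the data shown here, the one step that can be measured is an at least 1.3-fold higher number from compound 2 to compound 3 (0.14 log units; that floor lies within the scatter), and that floor lies within the scatter. Its size cannot be set more tightly because of the limit of > 25000 nM in this assay, at which 2 of the 3 values shown sit.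

Compound 4 `Cc1nc(NCc2ccccn2)nc(N[C@@H]2C[C@H](CO)[C@@H](O)[C@H]2O)c1-c1nc2ccccc2s1` differs from compound 2 by ((pyridin-2-yl)methyl)amino in place of dimethylamino on an aromatic carbon.

Among the measured compounds shown here, no measured step touches the dimethylamino group. For the measured compounds named here, the single step that is measured, an at least 1.3-fold higher number from compound 2 to compound 3 (0.14 log units; that floor lies within the scatter), concerns the methyl group in a different part of the shared core, so it bears on the new compound only in showing how little the readings in this assay move between these close analogues. The ((pyridin-2-yl)methyl)amino group brings one hydrogen-bond donor and a six-membered aromatic ring with one hetero atom where the dimethylamino group had none, but nothing in the data ties such a change to the read-out. No step beyond the scatter is therefore expected from compound 2 to compound 4. The expected step is a 1.1-fold higher number from compound 2 to compound 4 (0.05 log units; within the scatter). Compound 4 is expected at 20000 nM, with a range from 8000 nM to 60000 nM.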

Compound 4, half-maximal cytotoxic concentration: 13000 nM
Beside the measured number, compound 4's estimate is 1.5-fold (0.19 log units) above it; low and high end bracket the measured number.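

In this assay, the aromatic carbon between two ring nitrogen atoms now has a step of its own: ((pyridin-2-yl)methyl)amino in place of dimethylamino gives a 1.4-fold lower number from compound 2 to compound 4 (0.14 log units; within the scatter). This position therefore takes a group of 8 heavy atoms, with a six-membered aromatic ring and a hydrogen-bond donor, in place of one of 3 heavy atoms and no donor, and the reading stays within the scatter. This is also the only step in the series with a number at both ends, whereas the step on the methyl group can be read only as a floor, because of this: the limit of > 25000 nM in this assay, at which 2 of the 4 values shown sit.

Still open, going by these compounds, is whether a plain benzylamino group, with no ring nitrogen, or a morpholine on the same carbon would stay within the scatter as well. Also open, on these data alone, is whether a primary amine, or a chain ending in a carboxylic acid, at this position would move the number in this assay beyond the scatter in either direction.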